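A Second Nitro Group on a Weak Hydrazide Inhibitor

A few compounds are considered here, and "the series" means these few. Any claim that something is new, unique, unknown or untested is made for them only; others in the source may bear on it.

Of the compounds shown here, two sharing one core have been measured. Compound 1 `CCOC(=O)N1CCC(=NNC(=O)c2ccc(F)cc2)CC1` gives 74800 nM in a functional assay, read by spectrophotometry, with a stated time of 2 h; a higher number here means a weaker inhibitor, a lower number a stronger inhibitor. Compound 2 `CCOC(=O)N1CCC(=NNC(=O)c2ccc([N+](=O)[O-])cc2)CC1` gives 51700 nM in this assay. Among the compounds with values here, the only step recorded so far is a 1.4-fold lower number from compound 1 to compound 2 (0.16 log units; within the scatter), so the two numbers cannot be told apart, and compound 2 simply stands beside compound 1 at the bottom of a very short list.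

Compound 3 `CCOC(=O)N1CCC(=NNC(=O)c2ccc([N+](=O)[O-])cc2[N+](=O)[O-])CC1` is the next one. Compared with compound 2, it carries nitro in place of hydrogen on an aromatic carbon, so the ring now bears two nitro groups.

Within the data shown here, only one measured step bears on this: the exchange of fluoro for nitro, a 1.4-fold lower number from compound 1 to compound 2 (0.16 log units; within the scatter), which was within the scatter. Among the measured compounds shown here, no measured pair shows what a second nitro group on the same ring does. With that single step as a guide, no move beyond the scatter is expected in this assay for compound 3 in either direction.

Compound 3 is therefore estimated at 45000 nM in this assay, with a range from 18000 nM to 110000 nM. The expected step is a 1.1-fold lower number from compound 2 to compound 3 (0.06 log units; within the scatter).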

Compound 3, half-maximal inhibitory concentration: 60000 nM
Compound 3: middle estimate off by 1.3-fold (0.12 log units), on the low side, and the stated range covers the measured number.
By their numbers in this assay, from the lowest: compounds 2, 3 and 1 (each within the scatter of the next).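

Placing a nitro group on an aromatic carbon, ortho to a large group and meta to the nitro group already present, gives a 1.2-fold higher number from compound 2 to compound 3 (0.06 log units; within the scatter) in this assay, so the two numbers cannot be told apart. Within the data shown here, the earlier pair showed only one group exchanged for another on the ring, whereas this step shows a ring hydrogen replaced by a group of 3 heavy atoms, with compounds 2, 3 and 1 still each within the scatter of the next in order of their numbers. No supporting measurement on these compounds bears on this result.

Nitro is the only group shown at this position, so it remains open whether an amine, a methoxy group or a carboxylic acid on the same carbon would shift the number beyond the scatter in either direction. Also open, as far as these compounds go, is whether a second group on the ring of compound 1, which carries fluoro rather than nitro, would give the same picture.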